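Pyridin-2-yl in place of 3-methylphenyl on a shared core

The source may report more compounds than this note shows. Statements on the series, on what has been measured and on what is new or still open speak of the compounds shown alone.

Compound 1 `Cc1cccc(-c2cc(-c3ccc(Cl)o3)cc(-c3ccsc3)n2)c1` and compound 2 `Clc1ccc(-c2cc(-c3cccs3)nc(-c3ccccc3Cl)c2)o1` were examined in an assay on isolated protein for inhibition of DNA topoisomerase 1 (Homo sapiens), tested at 100 uM; on this read-out higher numbers stand for a stronger effect at the one concentration tested and lower numbers for a weaker effect. Compound 1 gives 7.5% in this assay, the lowest of the two numbers shown, while compound 2 gives 41.3%, a value higher by more than the usual scatter. Compound 3 `Clc1ccc(-c2cc(-c3ccsc3)nc(-c3ccccn3)c2)o1` has not yet been measured. It differs from compound 1 in one place: pyridin-2-yl in place of 3-methylphenyl on an aromatic carbon. For the measured compounds named here, no step between measured compounds covers this change, so the expectation rests on the two values alone. The expected step is small, upward or none beyond the scatter: a number 10.5 percentage points higher from compound 1 to compound 3 (beyond the scatter). Compound 3 is therefore estimated at 18%, in a range from 0% to 40%.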

Compound 3, a percentage reported as inhibition, at one concentration (the size of the read-out at that concentration, not a potency): 0%
The estimate for compound 3 lay 18 percentage points above the measured number; the range from low to high includes it.
By their numbers in this assay, from the lowest: compounds 3 and 1 (each within the scatter of the next); then compound 2.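

In this assay the exchange of 3-methylphenyl for pyridin-2-yl, on the aromatic carbon next to the ring nitrogen, produces a shift that stays inside the usual scatter (a number 7.5 percentage points lower from compound 1 to compound 3 (within the scatter)). With the 5-chlorofuran-2-yl and thiophen-3-yl groups held constant, the ring nitrogen of pyridin-2-yl therefore brings no readable gain at this position. Nothing available here explains this outcome. The compounds shown leave open whether an aminomethyl group or a carboxylic acid on this ring would move the read-out beyond the scatter.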